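Replacing a Nitro Group with a Sulfonyl Carbamoyl Group

This account rests on a few compounds, and the source may have more. Where it says the series, first, only, none or still open, it means among the compounds named here.

Of the compounds shown here, three sharing one core have been tested in an assay on microsomes from brain for inhibition of Fatty-acid amide hydrolase 1 (Rattus norvegicus), read by fluorescence and HPLC, with a stated time of 45 min; a higher number here means a weaker inhibitor, a lower number a stronger inhibitor. Compound 1 `O=C(COc1ccc(Oc2ccccc2)cc1)Cn1ncc2ccccc21` gives 2600 nM. Compound 2 `O=C(COc1ccc(Oc2ccccc2)cc1)Cn1ncc2cc(NC(=O)Oc3ccccc3)ccc21` gives 2100 nM, and compound 3 `O=C(COc1ccc(Oc2ccccc2)cc1)Cn1ncc2cc([N+](=O)[O-])ccc21` gives 550 nM. The step of a 1.2-fold lower number from compound 1 to compound 2 (0.09 log units; within the scatter) lies within the scatter, whereas a 4.7-fold lower number from compound 1 to compound 3 (0.67 log units; beyond the scatter) and a 3.8-fold lower number from compound 2 to compound 3 (0.58 log units; beyond the scatter) are both modest but real gains. Compound 3 therefore holds the lowest number of the three, with compound 2 as its nearest neighbour and compound 1 the furthest.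

Compound 4 `O=C(COc1ccc(Oc2ccccc2)cc1)Cn1ncc2cc(C(=O)NS(=O)(=O)c3ccccc3)ccc21` is the next candidate. Its change from compound 3 is (phenylsulfonyl)carbamoyl in place of nitro on an aromatic carbon. For the measured compounds named here, two measured steps bear on it: both a 4.7-fold lower number from compound 1 to compound 3 (0.67 log units; beyond the scatter) and a 3.8-fold lower number from compound 2 to compound 3 (0.58 log units; beyond the scatter) show that the nitro group at this position goes together with the strongest inhibition seen so far, and that a larger group on the nitrogen in compound 2 fared no better than hydrogen. Compound 4 exchanges the nitro group for another large group, so a modest move toward a higher number in this assay is expected. The estimate for compound 4 is 2000 nM, in a range from 700 nM to 6000 nM, which amounts to an expected step of a 3.6-fold higher number from compound 3 to compound 4 (0.56 log units; beyond the scatter).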

Compound 4, half-maximal inhibitory concentration: 4700 nM
Estimate against measurement, compound 4: 2.4-fold (0.37 log units) below, and the stated range covers the measured number.
By their numbers in this assay, from the lowest: compound 3; then compounds 2, 1 and 4 (each within the scatter of the next, the first and the last beyond it).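

Putting (phenylsulfonyl)carbamoyl in place of nitro on this aromatic carbon gives the largest step in the series in this assay, with an 8.5-fold higher number from compound 3 to compound 4 (0.93 log units; beyond the scatter), so the advantage seen with nitro does not carry over to this much bigger group. Set against the parent without a substituent, the new group makes no difference that can be told from the scatter, with a 1.8-fold higher number from compound 1 to compound 4 (0.26 log units; within the scatter), which means this position tolerates the group without any gain or any clear loss. The comparison between the two bigger groups, a 2.2-fold higher number from compound 2 to compound 4 (0.35 log units; beyond the scatter), shows that they are not interchangeable here, even though each lies within the scatter of compound 1 on its own.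

No measurement shown here explains why nitro stands apart from the other groups at this position. On these data alone, it also remains open whether a nitrile, a carboxylic acid or an amine on the same aromatic carbon would hold the number of compound 3, or whether nitro is alone in giving that gain.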